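Trading a Chlorophenyl for a Thiophen-2-yl Group

A few compounds are considered here, and "the series" means these few. Any claim that something is new, unique, unknown or untested is made for them only; others in the source may bear on it.

Three compounds share one core and differ only in the aryl group on a carbon with a double bond to nitrogen. Compound 1 `CC1=CC[C@H](C(C)(C)NC(=S)N/N=C/c2ccc(O)cc2)CC1` carries a 4-hydroxyphenyl there. In a functional assay on OVCAR-3 cells (Homo sapiens) for inhibition, read by sulforhodamine B assay, with a stated time of 48 h (a lower number here means a stronger inhibitor of growth, a higher number a weaker inhibitor of growth), compound 1 gives > 100000 nM, which is a limit of the assay rather than a number. Compound 2 `CC1=CC[C@H](C(C)(C)NC(=S)N/N=C/c2ccccc2Cl)CC1` gives 15100 nM in this assay, and compound 3 `CC1=CC[C@H](C(C)(C)NC(=S)N/N=C/c2cccc(Cl)c2)CC1` gives 13600 nM. The steps are an at least 6.6-fold lower number from compound 1 to compound 2 (0.82 log units; beyond the scatter) and an at least 7.3-fold lower number from compound 1 to compound 3 (0.86 log units; beyond the scatter), whereas a 1.1-fold lower number from compound 2 to compound 3 (0.05 log units; within the scatter). Compound 3 thus holds the lowest of the two numbers, with compound 2 within the scatter of it. Compound 4 `CC1=CC[C@H](C(C)(C)NC(=S)N/N=C/c2cccs2)CC1` differs from compound 3 by thiophen-2-yl in place of 3-chlorophenyl on a carbon with a double bond to nitrogen. Within the data shown here, no measured step exchanges a chlorophenyl for a five-membered ring; the only step between two numbers, a 1.1-fold lower number from compound 2 to compound 3 (0.05 log units; within the scatter), shows that relocating the chlorine changed little. A small step is therefore expected, a 1.5-fold higher number from compound 3 to compound 4 (0.17 log units; within the scatter). Compound 4 is estimated at 20000 nM, likely between 7000 nM and 60000 nM.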

Compound 4, concentration for 50% growth inhibition: 13100 nM
For compound 4 the middle estimate is 1.5-fold (0.18 log units) above the measured one; the range from low to high includes it.
By their numbers in this assay, from the lowest: compounds 4, 3 and 2 (each within the scatter of the next). At a limit, above all of these: compound 1.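

A chlorophenyl is not required at this position: with the five-membered thiophen-2-yl on the carbon with a double bond to nitrogen, the numbers stay level, with a 1.0-fold lower number from compound 3 to compound 4 (0.02 log units; within the scatter) and a 1.2-fold lower number from compound 2 to compound 4 (0.06 log units; within the scatter). Among these compounds, only the 4-hydroxyphenyl of compound 1 stands apart, with an at least 7.6-fold lower number from compound 1 to compound 4 (0.88 log units; beyond the scatter). That step rests on a limit, not a number: the limit of > 100000 nM in this assay, at which 1 of the 4 values shown sits.

The compounds shown leave open how an amine, a carboxylic acid or a longer chain would fare at this position. They also leave open whether any group here can give a much lower number.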